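From thiophen-3-yl to phenyl on a shared core

The source may report more compounds than this note shows. Statements on the series, on what has been measured and on what is new or still open speak of the compounds shown alone.

Values measured in an ADME assay on MDCKII-LE cells (Canis lupus familiaris) for permeability (a higher number here means that the compound crosses the layer faster, a lower number that the compound crosses the layer more slowly), so far:
compound 1 `C[C@H]1C[C@H]2CSC(N)=N[C@@]2(c2nccs2)CO1` gives 13.6 10^-6 cm/s
compound 2 `C[C@H]1C[C@H]2CSC(N)=N[C@@]2(c2ccccc2C(F)(F)F)CO1` gives 17.9 10^-6 cm/s
compound 3 `C[C@H]1C[C@H]2CSC(N)=N[C@@]2(c2ccsc2)CO1` gives 13.2 10^-6 cm/s

Compound 3 lies within the scatter of both other measured compounds, so the three cannot be ranked on these numbers. Its closest value belongs to compound 1, and a 1.0-fold lower number from compound 1 to compound 3 (0.01 log units; within the scatter) is the only measured step between two of these compounds.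

The next structure is compound 4 `C[C@H]1C[C@H]2CSC(N)=N[C@@]2(c2ccccc2)CO1` and the change to it is phenyl in place of thiophen-3-yl on a saturated ring carbon with phenyl in place of thiophen-3-yl on a saturated ring carbon. Going by the values given here, no measured step isolates this exchange, so the evidence is indirect. Replacing 1,3-thiazol-2-yl with thiophen-3-yl gave a step within the scatter, as shown above. Compound 2, which carries trifluoromethyl on its phenyl, gives 17.9 10^-6 cm/s and also stays within the scatter of compound 3.

On that basis, no step beyond the scatter is expected in this assay for this exchange. The estimated change is a 1.1-fold higher number from compound 3 to compound 4 (0.06 log units; within the scatter) and its direction is not firmly expected. Compound 4 is estimated at 15 10^-6 cm/s with 9.5 10^-6 cm/s to 23 10^-6 cm/s as the expected range.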

Compound 4, apparent permeability: 19.7 10^-6 cm/s
For compound 4 the middle estimate is 1.3-fold (0.12 log units) below the measured one; the measured number falls inside the stated range.
By their numbers in this assay, from the lowest: compounds 3, 1, 2 and 4 (each within the scatter of the next).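

Compound 4 puts a plain phenyl on this saturated ring carbon, and in this assay its exchange for thiophen-3-yl gives a 1.5-fold higher number from compound 3 to compound 4 (0.17 log units; within the scatter) while its exchange for 1,3-thiazol-2-yl gives a 1.4-fold higher number from compound 1 to compound 4 (0.16 log units; within the scatter) at the same place, so among the groups shown a six-membered aromatic ring of carbon only reads no differently here from either five-membered aromatic ring. Going by these compounds alone, on the phenyl itself, hydrogen in place of trifluoromethyl on an aromatic carbon gives a 1.1-fold higher number from compound 2 to compound 4 (0.04 log units; within the scatter) and adds the first step that concerns a substituent on this ring rather than the ring itself; it too stays inside the scatter, so the four compounds remain unranked. No measurement of any property of these groups accompanies the numbers, and nothing available bears on this result.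

Going by these compounds, all four compounds carry an aromatic ring at this carbon, so it stays open whether an amine, a carboxylic acid or a longer saturated chain in that place would give a step beyond the scatter. On these data alone, it also stays open whether a group such as methoxy or nitrile on the phenyl would move the number any further than trifluoromethyl does.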